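Does one more chain carbon change compound 2?

A few compounds are considered here, and "the series" means these few. Any claim that something is new, unique, unknown or untested is made for them only; others in the source may bear on it.

Compound 1 `COc1ccc(N(C)c2nc(C)nc3ccccc23)cc1C(=O)OCCC[Se]C#N` gives 1180 nM
Compound 2 `COc1ccc(N(C)c2nc(C)nc3ccccc23)cc1OCCCC[Se]C#N` gives 1350 nM

Both values come from a functional assay on MDA-MB-231 cells (Homo sapiens) for inhibition, read by MTT assay, with a stated time of 48 h; a lower number here means a stronger inhibitor, a higher number a weaker inhibitor. There, compound 2 at 1350 nM stands level with compound 1, the gap between them being within the usual scatter of repeated measurements.

The next compound to test is compound 3 `COc1ccc(N(C)c2nc(C)nc3ccccc23)cc1OCCCCC[Se]C#N`. It differs from compound 2 in one place: a group of 4 heavy atoms (2 carbon, 1 nitrogen, 1 selenium; no ring) in place of a group of 3 heavy atoms (1 carbon, 1 nitrogen, 1 selenium; no ring), on a saturated chain carbon, four bonds along the chain from an oxygen on an aromatic ring.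

Within the data shown here, only one measured step can guide the expectation: a 1.1-fold higher number from compound 1 to compound 2 (0.06 log units; within the scatter). That step also alters the side chain, but it does not simply lengthen it, so it is a weak guide. Since it stayed within the scatter, no clear shift in either direction is expected in this assay.

The expected change is a 1.1-fold lower number from compound 2 to compound 3 (0.03 log units; within the scatter).

For compound 3 the estimated value is 1250 nM, with an expected range from 550 nM to 2800 nM.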

Compound 3, half-maximal inhibitory concentration: 4410 nM
Beside the measured number, compound 3's estimate is 3.5-fold (0.55 log units) below it, outside the stated range (above it).
By their numbers in this assay, from the lowest: compounds 1 and 2 (each within the scatter of the next); then compound 3.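

In this assay, one more carbon in this saturated chain, four bonds along the chain from an oxygen on an aromatic ring, gives a 3.3-fold higher number from compound 2 to compound 3 (0.51 log units; beyond the scatter), so chain length at this position matters and a single added carbon is enough to weaken inhibition beyond the scatter. The comparison with the ester-linked side chain points the same way, with a 3.7-fold higher number from compound 1 to compound 3 (0.57 log units; beyond the scatter), which leaves compound 3 as the weakest inhibitor of the three, while compounds 1 and 2 remain level. No measurement shown explains why the extra carbon weakens inhibition.

On these data alone, a single added carbon gives one step rather than a trend, so it remains open whether a longer chain would weaken inhibition further or a shorter chain would strengthen it. As far as these compounds go, it is also open whether the end of the chain matters as much, for example if sulfur replaced the selenium.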